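Replacing a pyridine with chlorophenyl on the shared core

A few compounds are considered here, and "the series" means these few. Any claim that something is new, unique, unknown or untested is made for them only; others in the source may bear on it.

Among the measured compounds shown here, compound 2 `Cc1nc(-c2cccnc2)sc1-c1nnc(-c2cccnc2)o1` is one of three compounds measured in an ADME assay on HCT-116 cells (Homo sapiens) for cytotoxicity, read by MTT assay; on this read-out lower numbers stand for higher toxicity in this test and higher numbers for lower toxicity in this test. In this assay compound 2 gives > 100 ug/mL, which is a limit of the assay rather than a number. Compound 1 `Cc1nc(-c2cccnc2)sc1-c1nnc(-c2ccncc2)o1` likewise reaches only a limit, > 100 ug/mL. Compound 3 `Cc1cccc(-c2nnc(-c3sc(-c4cccnc4)nc3C)o2)c1` also gives only a limit, > 100 ug/mL. All three values therefore sit together: the limit of > 100 ug/mL in this assay, at which 3 of the 3 values shown sit. Both ends of the steps a step that the two limits leave unreadable from compound 1 to compound 2, a step that the two limits leave unreadable from compound 1 to compound 3 and a step that the two limits leave unreadable from compound 2 to compound 3 are limits, so their sizes cannot be read. Compound 4 `Cc1nc(-c2cccnc2)sc1-c1nnc(-c2ccccc2Cl)o1` differs from compound 2 by 2-chlorophenyl in place of pyridin-3-yl on an aromatic carbon. For the measured compounds named here, no measured step bears on this change, and nothing among the three compounds places any value away from the limit. Compound 4 is therefore expected to give about 120 ug/mL (range 70 ug/mL to 200 ug/mL), a step that the limit leaves unreadable from compound 2 to compound 4 that is expected to lie within the scatter.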

Compound 4, half-maximal cytotoxic concentration: > 100 ug/mL
Compound 4: only a limit was reported (the forecaster's own chance of this, stated with the estimate: 75%); the middle value lies beyond the limit too.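

In this assay, among the compounds shown here, compound 4 gives > 100 ug/mL, which is a limit, so no step to compound 4 from compound 1, compound 2 or compound 3 can be read: the limit of > 100 ug/mL in this assay, at which 4 of the 4 values shown sit. The compounds shown leave open whether any change on the shared core gives a value away from this limit.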